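The compounds below may be only part of what the source reports. "The series", "measured", "known", "first", "only" and "open" are said of these compounds alone.

Measured in a functional assay on M21 cells (Homo sapiens) for inhibition, read by sulforhodamine B assay, with a stated time of 48 h; a higher number here means a weaker inhibitor, a lower number a stronger inhibitor:
- compound 1 `CCNC(=O)Nc1ccc(/C=C\c2cccc(Cl)c2)cc1`: 35000 nM
- compound 2 `CCNC(=O)Nc1ccc(/C=C\c2cc(C)cc(C)c2)cc1`: 16000 nM

Of these two numbers, compound 2 holds the lower at 16000 nM, and the gap to compound 1 at 35000 nM lies beyond the scatter. Compound 3 `Cc1cc(C)cc(/C=C\c2ccc(N3CCNC3=O)cc2)c1` has not yet been measured in this assay. It departs from compound 2 in one place, on an aromatic carbon of a six-membered aromatic ring of carbon only, para to a large group, where 2-oxoimidazolidin-1-yl stands in place of (ethylcarbamoyl)amino (2-oxoimidazolidin-1-yl in place of (ethylcarbamoyl)amino on an aromatic carbon). Among the compounds with values here, no measured pair shows this change, so its size cannot be read from the data. Within the data shown here, only a small shift towards a stronger inhibitor is expected, with no step clearly beyond the scatter. The estimated step is a 1.6-fold lower number from compound 2 to compound 3 (0.20 log units; within the scatter). For compound 3 the estimated value is 10000 nM, with an expected range of 2500 nM to 40000 nM.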

Compound 3, half-maximal inhibitory concentration: 10 nM
Compound 3: the middle estimate sits 1000-fold (3.00 log units) above what was measured; the whole stated range lies above it.
By their numbers in this assay, from the lowest: compound 3; then compound 2; then compound 1.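

In this assay, within the data shown here, replacing (ethylcarbamoyl)amino with 2-oxoimidazolidin-1-yl gives a 1600-fold lower number from compound 2 to compound 3 (3.20 log units; beyond the scatter), which shows that this place on the aromatic ring, para to a large group, can govern the read-out to a degree the earlier compounds could not reveal, since both carry the same (ethylcarbamoyl)amino group there. The two groups hold the same heavy atoms, yet the entering group carries a five-membered non-aromatic ring and fewer hydrogen-bond donors, and this single change cannot separate those two differences. Nothing at hand gives a reason for a step of this size.

From the compounds shown here alone, it remains open whether the ring or the donor count matters; a methyl group on the free ring nitrogen or a six-membered cyclic urea would bear on that. Also open, going by these compounds, is whether the same change gives a like step on the core of compound 1.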